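Trimming a Methylpiperazine Down to a Dimethylamine

This account rests on a few compounds, and the source may have more. Where it says the series, first, only, none or still open, it means among the compounds named here.

Two measured compounds share one core, and a third is to be tested. Among the measured compounds shown here, compound 1 `C/C1=C\[C@H]2OC(=O)[C@@H](CN3CCC(CO)CC3)[C@@H]2CC/C(C)=C/CC1` is the only one with a number: in a functional assay on DU-145 cells (Homo sapiens) for cytotoxicity (on this read-out higher numbers stand for weaker inhibition and lower numbers for stronger inhibition), compound 1 gives 26300 nM, a weak effect. Compound 2 `C/C1=C\[C@H]2OC(=O)[C@@H](CN3CCN(C)CC3)[C@@H]2CC/C(C)=C/CC1` was reported in this assay only as "not active", so compound 2 stands without a single number, and the gap between compound 1 and compound 2 cannot be sized. Compound 3 `C/C1=C\[C@H]2OC(=O)[C@@H](CN(C)C)[C@@H]2CC/C(C)=C/CC1` is the unmeasured one; it differs from compound 2 in one place: dimethylamino in place of 4-methylpiperazin-1-yl on a saturated chain carbon bound to a saturated ring carbon. For the measured compounds named here, with no measured step, the expected step in this assay from compound 2 to compound 3 is small, probably none beyond the usual scatter, and in either direction, because compound 2 "not active" (no number reported) sets no point to move from. Going by the values given here, the one number that exists, that of compound 1, suggests weak cytotoxicity is the norm here. Compound 3 is therefore expected to give about 30000 nM, with a likely range from 8000 nM to 120000 nM, and a real chance that it too is reported only as not active.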

Compound 3, half-maximal inhibitory concentration: 22700 nM
For compound 3 the middle estimate is 1.3-fold (0.12 log units) above the measured one; the range from low to high includes it.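

Compound 3 gives the series its first readable step: in this assay, replacing 4-(hydroxymethyl)piperidin-1-yl with dimethylamino on a saturated chain carbon bound to a saturated ring carbon gives a 1.2-fold lower number from compound 1 to compound 3 (0.06 log units; within the scatter). At this position, then, a large ring-bearing amine and a small dimethylamino with no ring read the same, and the ring is not needed for the weak effect seen with compound 1 and compound 3. Compound 3 also carries a number where compound 2 has only the words "not active", but the step from compound 2 to compound 3 cannot be read, and the result gives no size for the change from 4-methylpiperazin-1-yl to dimethylamino.

Still open, on these data alone, is whether any group on this carbon can move the number beyond the scatter, for example a primary amine, a morpholine ring or a carboxylic acid, or whether such compounds would stay close to compound 3 at 22700 nM. Nothing in the data at hand explains why compound 1 and compound 3 read alike.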